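Compound 4: cyano replacing trifluoromethoxy in the series

The source may hold more compounds than are shown below. What is called first, only, known or untested is meant among the compounds shown, and "the series" means these compounds.

Of the compounds shown here, three have so far been measured in an assay on isolated protein for displacement of a labelled ligand from Apoptosis regulator Bcl-2 (Homo sapiens), read by fluorescence polarization; on this read-out higher numbers stand for weaker inhibition and lower numbers for stronger inhibition. Compound 1 `CN(C)CC[C@H](CSc1ccccc1)Nc1ccc(S(=O)(=O)NC(=O)c2ccc(N3CCN(Cc4ccccc4-c4ccc(Cl)cc4)CC3)cc2)cc1OC(F)(F)F` reaches only a limit of this assay, giving < 1 nM. Compound 2 `CN(C)CC[C@H](CSc1ccccc1)Nc1ccc(S(=O)(=O)NC(=O)c2ccc(N3CCN(CC4=C(c5ccc(Cl)cc5)CCC4)CC3)cc2)cc1[N+](=O)[O-]` likewise returns a limit in this assay, < 1 nM. Compound 3 `CN(C)CC[C@H](CSc1ccccc1)Nc1ccc(S(=O)(=O)NC(=O)c2ccc(N3CCN(C/C4=C(\c5ccc(Cl)cc5)CCCCCC4)CC3)cc2)cc1[N+](=O)[O-]` also stands at a limit in this assay, < 1 nM. Among the compounds with values here, what is known of compound 1 is therefore (the limit of < 1 nM in this assay, at which 3 of the 3 values shown sit); the three values cannot be placed in any order, and no step between measured compounds can be drawn from them.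

Compound 4 `CN(C)CC[C@H](CSc1ccccc1)Nc1ccc(S(=O)(=O)NC(=O)c2ccc(N3CCN(Cc4ccccc4-c4ccc(Cl)cc4)CC3)cc2)cc1C#N` has not been measured. It differs from compound 1 in one place: cyano in place of trifluoromethoxy on an aromatic carbon. The trifluoromethoxy leaves and the cyano enters, on an aromatic carbon of a six-membered aromatic ring of carbon only, ortho to a large group and meta to a large group. Since compound 1 already sits at the limit with < 1 nM, the step that the limit leaves unreadable from compound 1 to compound 4 is expected to be none beyond the scatter, with compound 4 most likely again returning a limit. For compound 4 the estimated value in this assay is 0.8 nM, with a range from 0.2 nM to 3 nM.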

Compound 4, inhibition constant: < 1 nM
Compound 4: a limit, no number; the forecaster's own chance of this, stated with the estimate: 70%; the middle value lies beyond the limit too.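

Compound 1 and compound 4 each return only a limit, so no step can be read for cyano in place of trifluoromethoxy on an aromatic carbon. The compounds shown leave open how far any of them differ in this assay, because all stand at one limit: the limit of < 1 nM in this assay, at which 4 of the 4 values shown sit.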